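Step from compound 2 to compound 4

This account rests on a few compounds, and the source may have more. Where it says the series, first, only, none or still open, it means among the compounds named here.

Three members of the series have been measured in an assay on CHO-K1 cells for displacement of a labelled ligand from melanin-concentrating hormone receptor 1 (Homo sapiens), read by scintillation proximity assay, with a stated time of 2 h; on this read-out higher numbers stand for weaker inhibition and lower numbers for stronger inhibition. Compound 1 `Cc1nc(NCCNC(=O)C2CC2)nc2ccc(NC(=O)/C=C/c3ccc(OC(F)(F)F)cc3)cc12` gives 61 nM. Compound 2 `COCC(=O)NC1CCN(c2nc(C)c3cc(NC(=O)/C=C/c4ccc(OC(F)(F)F)cc4)ccc3n2)CC1` gives 32 nM. Compound 3 `Cc1nc(NCCNS(C)(=O)=O)nc2ccc(NC(=O)/C=C/c3ccc(OC(F)(F)F)cc3)cc12` gives 169 nM. Compound 2 holds the lowest number of the three, though the gap to compound 1, a 1.9-fold lower number from compound 1 to compound 2 (0.28 log units; within the scatter), is within the scatter; only the gap to compound 3, a 5.3-fold higher number from compound 2 to compound 3 (0.72 log units; beyond the scatter), lies beyond it.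

Compound 4 `Cc1nc(N2CCC(N3C(=O)CCC3=O)CC2)nc2ccc(NC(=O)/C=C/c3ccc(OC(F)(F)F)cc3)cc12` carries 2,5-dioxopyrrolidin-1-yl in place of ((methoxymethyl)carbonyl)amino on a saturated ring carbon. The nearest measured precedent is the exchange of cyclopropylcarbonyl for methylsulfonyl on the amine nitrogen, a 2.8-fold higher number from compound 1 to compound 3 (0.44 log units; beyond the scatter), a modest loss. Going by the values given here, no measured step closes a ring at this position or ends in a group with 0 hydrogen-bond donors, so the change in compound 4 goes further than anything measured. Given that even the gentler swap, a 2.8-fold higher number from compound 1 to compound 3 (0.44 log units; beyond the scatter), moved the number beyond the scatter, a loss is the more likely outcome. For compound 4 a modest rise is expected, a 2.5-fold higher number from compound 2 to compound 4 (0.40 log units; beyond the scatter). Among the compounds with values here, the range is kept wide; the step has no close measured analogue. The estimate for compound 4 in this assay is 80 nM, expected to fall between 30 nM and 250 nM.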

Compound 4, half-maximal inhibitory concentration: 94 nM
Estimate against measurement, compound 4: 1.2-fold (0.07 log units) below; measured number inside the range.
By their numbers in this assay, from the lowest: compounds 2, 1, 4 and 3 (each within the scatter of the next, the first and the last beyond it).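

In this assay, going by these compounds alone, this is the first change made on the saturated ring carbon of the six-membered non-aromatic ring with 1 nitrogen while the rest of compound 2 stays fixed, and it gives a 2.9-fold higher number from compound 2 to compound 4 (0.47 log units; beyond the scatter) as a modest step. Within the data shown here, the number therefore responds to the group at this place alone, whereas the earlier steps either exchanged the whole substituent on the aromatic carbon or changed an acyl-type group on the amine nitrogen of an open chain. The step combines several changes, as the open ((methoxymethyl)carbonyl)amino with 1 hydrogen-bond donor gives way to the closed 2,5-dioxopyrrolidin-1-yl with 0 hydrogen-bond donors and one more heavy atom, and no measurement is available that separates these changes or accounts for the step.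

The compounds shown leave open whether removing the amide hydrogen or closing the ring carries the step: an N-methyl amide keeps the chain open without that hydrogen, while a pyrrolidin-2-one keeps a ring with a single carbonyl. A free primary amine or a carboxylic acid on the same carbon would show how far this place tolerates groups without the carbonyl-containing substituent.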